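Extending the acid chain and removing the amide link

The source may report more compounds than this note shows. Statements on the series, on what has been measured and on what is new or still open speak of the compounds shown alone.

Of the compounds shown here, three that share a core have been measured in an ADME assay on microsomes from liver (Homo sapiens) for metabolic stability, using NADPH, with a stated time of 60 min, in the presence of a further agent that is not named here; a lower number here means slower removal, a higher number faster removal of the compound. Compound 1 `O=C(O)CNC(=O)COc1ccc([C@H]2CC[C@]3(CC2)OOC2(O3)C3CC4CC(C3)CC2C4)cc1` gives < 7 mL.min-1.g-1; this is a limit of the assay and not a number. Compound 2 `O=C(O)COc1ccc([C@H]2CC[C@]3(CC2)OOC2(O3)C3CC4CC2CC(C3)C4(F)F)cc1` gives 23 mL.min-1.g-1, and compound 3 `O=C(O)c1cc([C@H]2CC[C@]3(CC2)OOC2(O3)C3CC4CC(C3)CC2C4)ccc1O` gives 108 mL.min-1.g-1. Compound 1 thus stands at the slow end of the three values shown, at the limit of < 7 mL.min-1.g-1 in this assay, at which 1 of the 3 values shown sits, while compound 3 is removed fastest among them.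

Compound 4 `O=C(O)CCCOc1ccc([C@H]2CC[C@]3(CC2)OOC2(O3)C3CC4CC(C3)CC2C4)cc1` has not yet been measured in this assay. It differs from compound 1 in one place: 2-carboxyethyl in place of (carboxymethyl)carbamoyl on a saturated chain carbon bound to an oxygen on an aromatic ring. Among the measured compounds shown here, no measured pair in this set shows the effect of such a change, so the expectation for compound 4 rests on the spread of the three values alone. Since the plain acid of compound 2 gives 23 mL.min-1.g-1, a modest move toward faster removal is expected, an at least 2.1-fold higher number from compound 1 to compound 4 (0.33 log units; beyond the scatter), though this could fall within the usual scatter. Compound 4 is therefore estimated at 15 mL.min-1.g-1, with a range from 5 mL.min-1.g-1 to 45 mL.min-1.g-1.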

Compound 4, intrinsic clearance in microsomes: < 7 mL.min-1.g-1
Compound 4 gave a limit, no number; the forecaster's own chance of this, stated with the estimate: 30%; at least 2.1-fold (0.33 log units) between middle value and limit.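

Among the compounds shown here, compound 1 and compound 4 each give a limit of the assay and not a number, so no step between them can be read: (the limit of < 7 mL.min-1.g-1 in this assay, at which 2 of the 4 values shown sit). The compounds shown leave open whether 2-carboxyethyl in place of (carboxymethyl)carbamoyl changes the result in this assay at all, and by how much.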